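The compounds below may be only part of what the source reports. "The series", "measured", "known", "first", "only" and "open" are said of these compounds alone.

In an ADME assay on MDBK cells (Bos taurus) for cytotoxicity (a higher number here means that more compound is tolerated, a lower number that less compound is tolerated), compound 2 `COc1ccccc1Cn1ccc2nc(-c3ccccc3)nc-2c1` gives only a limit, > 100000 nM. Compound 1 `c1ccc(Cn2ccc3nc(-c4ccccc4)nc-3c2)cc1` likewise reaches only a limit in this assay, > 100000 nM. For the measured compounds named here, the one measured step, a step that the two limits leave unreadable from compound 1 to compound 2, cannot be sized because both values sit at the limit of > 100000 nM in this assay, at which 2 of the 2 values shown sit. Compound 3 `Clc1cccc(Cn2ccc3nc(-c4ccccc4)nc-3c2)c1` differs from compound 2 by 3-chlorophenyl in place of 2-methoxyphenyl on a saturated chain carbon bound to an aromatic nitrogen. No readable step bears on this change. Compound 3 is therefore expected to stay at the tolerated limit, with a step that the limit leaves unreadable from compound 2 to compound 3 that is no more than scatter. For compound 3 the estimate in this assay is 150000 nM, between 60000 nM and 400000 nM.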

Compound 3, half-maximal cytotoxic concentration: > 100000 nM
Compound 3 was reported as a limit; the forecaster's own chance of this, stated with the estimate: 85%; the middle value does not contradict the limit.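

For the compounds shown here, no step among compound 1, compound 2 and compound 3 can be read in this assay, because all three values are limits: the limit of > 100000 nM in this assay, at which 3 of the 3 values shown sit. The compounds shown leave open at what concentration any of them becomes cytotoxic, and whether the changes among them alter it.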